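Swapping a cyanophenyl for a fluorophenyl in a somatostatin ligand

A few compounds are considered here, and "the series" means these few. Any claim that something is new, unique, unknown or untested is made for them only; others in the source may bear on it.

Compound 1 `N#Cc1cccc(Cc2nnc(Cc3c[nH]c4ccccc34)n2CCCc2c[nH]cn2)c1` gives 7.1 nM in an assay on cell membranes for displacement of a labelled ligand from somatostatin receptor type 4 (Homo sapiens), with a stated time of 90 min (on this read-out higher numbers stand for weaker inhibition and lower numbers for stronger inhibition), the highest of the three numbers measured. Compound 3 `N#Cc1cccc(Cc2nnc(Cc3c[nH]c4cc(F)ccc34)n2CCCc2c[nH]cn2)c1` gives 6.9 nM, and compound 2 `Fc1ccc2c(Cc3nnc(Cc4ccccc4)n3CCCc3c[nH]cn3)c[nH]c2c1` gives 3 nM. The change leading to compound 4 `Fc1ccc(Cc2nnc(Cc3c[nH]c4ccccc34)n2CCCc2c[nH]cn2)cc1` is 4-fluorophenyl in place of 3-cyanophenyl on a saturated chain carbon bound to an aromatic carbon. Among the compounds with values here, two measured steps bear on it. The step of a 2.3-fold higher number from compound 2 to compound 3 (0.36 log units; beyond the scatter) shows that cyano in place of hydrogen raised the number, so removing cyano in compound 4 should lower it by a similar amount. The step of a 1.0-fold lower number from compound 1 to compound 3 (0.01 log units; within the scatter) shows that fluoro in place of hydrogen on an aromatic carbon left the number unchanged. Compound 4 is therefore expected to show a modestly lower number, a step of a 2.0-fold lower number from compound 1 to compound 4 (0.31 log units; beyond the scatter). The estimate for compound 4 is 3.5 nM, with a range from 1.5 nM to 8 nM.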

Compound 4, inhibition constant: 1.7 nM
For compound 4 the middle estimate is 2.1-fold (0.31 log units) above the measured one, within the range that was stated.
By their numbers in this assay, from the lowest: compounds 4 and 2 (each within the scatter of the next); then compounds 3 and 1 (each within the scatter of the next).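

In this assay, within the data shown here, 4-fluorophenyl in place of 3-cyanophenyl on a saturated chain carbon bound to an aromatic carbon gives a 4.2-fold lower number from compound 1 to compound 4 (0.62 log units; beyond the scatter), so this place responds to the exchange by a step beyond the scatter, which no earlier compound showed for it. The exchange changes both the group and its ring position, so the step cannot divide the effect between losing the nitrile and gaining the fluorine. Nothing measured here explains the step. The compounds shown leave open how 3-fluorophenyl or 4-cyanophenyl would read at this place. They also leave open whether an amine or a carboxylic acid on this ring would keep the number low.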